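The source may report more compounds than this note shows. Statements on the series, on what has been measured and on what is new or still open speak of the compounds shown alone.

Compound 1, `COc1ccc(-c2ccc3oc(NC4CCCCC4)nc3c2)cc1C`, gives 228 nM in an assay on HEK293 cells for inhibition of Fatty-acid amide hydrolase 1 (Homo sapiens), read by fluorescence; a higher number here means a weaker inhibitor, a lower number a stronger inhibitor.
Compound 2, `Cn1ncc2c(-c3ccc4oc(NC5CCCCC5)nc4c3)cccc21`, gives 52 nM in this assay.
Compound 3, `COc1ccc(Nc2nc3cc(-c4ccc5c(ccn5C)c4)ccc3o2)cc1`, gives 280 nM in this assay.

Among these three, compound 3 carries the highest number. Its gap to compound 1 is within the usual scatter, so the two cannot be ranked against each other; its gap to compound 2 is beyond the scatter, and compound 2 sits clearly lower. All three measured compounds keep an amino linkage on the shared core, while compound 4, `C[C@@H]1CN(c2nc3cc(-c4ccc5c(ccn5C)c4)ccc3o2)C[C@H](C)O1`, does not: the change is 2,6-dimethylmorpholin-4-yl in place of (4-methoxyphenyl)amino on an aromatic carbon. Going by the values given here, no measured pair shows this kind of swap, so there is no step to lean on, and the hydrogen-bond donor that all measured compounds share is lost. The expected step of a 2.5-fold higher number from compound 3 to compound 4 (0.40 log units; beyond the scatter) is therefore a moderate move toward a higher number, beyond the scatter but not large. Compound 4 is expected to give about 700 nM in this assay, estimated between 150 nM and 3500 nM.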

Compound 4, half-maximal inhibitory concentration: 168 nM
For compound 4 the middle estimate is 4.2-fold (0.62 log units) above the measured one, and the stated range covers the measured number.
By their numbers in this assay, from the lowest: compound 2; then compounds 4, 1 and 3 (each within the scatter of the next).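

Putting 2,6-dimethylmorpholin-4-yl in place of (4-methoxyphenyl)amino on this aromatic carbon, next to the ring nitrogen and the ring oxygen, gives a 1.7-fold lower number from compound 3 to compound 4 (0.22 log units; within the scatter) in this assay, so the two compounds cannot be ranked. In this one pair, then, a value in the same range does not depend on keeping the hydrogen-bond donor or the carbon-only aromatic ring of the group that leaves. No separate measurement bears on why these two different groups read alike.

Still open, from the compounds shown here alone, is how a morpholin-4-yl without its two methyl groups, or a small open-chain amine such as dimethylamino, would read on this carbon. Also open, going by these compounds, is whether the same swap would read alike starting from compound 2, which carries cyclohexylamino and gives 52 nM.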